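The source may hold more compounds than are shown below. What is called first, only, known or untested is meant among the compounds shown, and "the series" means these compounds.

Measured compounds:
compound 1 `CCC(CC)c1ccc2c(NCCCNCc3cccc(OC)c3O)ccnc2c1`, 410 nM
compound 2 `COc1cccc(CNCCCNc2ccnc3cc(Cc4ccc(F)cc4)ccc23)c1O`, 4780 nM
compound 3 `COc1cccc(CNCCCNc2ccnc3cc(-c4cccc5ccccc45)ccc23)c1O`, 2520 nM

In an ADME assay on HepG2 cells (Homo sapiens) for cytotoxicity, read by luminescence, CellTiter-Glo and ATP content, with a stated time of 72 h (on this read-out lower numbers stand for an effect already at smaller amounts and higher numbers for an effect only at larger amounts of compound), compound 1 gives 410 nM, compound 2 gives 4780 nM and compound 3 gives 2520 nM. Compound 3 therefore holds the second highest of the three numbers. Its nearest neighbour is compound 2, and the gap between them, a 1.9-fold lower number from compound 2 to compound 3 (0.28 log units; within the scatter), lies within the scatter, so the two cannot be ordered. Compound 1 lies furthest away, and the step of a 6.1-fold higher number from compound 1 to compound 3 (0.79 log units; beyond the scatter) is beyond the scatter.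

Compound 4 `COc1cccc(CNCCCNc2ccnc3cc(Cc4cc(C)cc(C)c4)ccc23)c1O` carries the change (3,5-dimethylbenzyl in place of naphthalen-1-yl on an aromatic carbon). Within the data shown here, two measured steps bear on it. The step of a 12-fold higher number from compound 1 to compound 2 (1.07 log units; beyond the scatter) shows that a benzyl group in this position, in place of pentan-3-yl, brought a large rise in this assay. The step of a 1.9-fold lower number from compound 2 to compound 3 (0.28 log units; within the scatter), which exchanges 4-fluorobenzyl for naphthalen-1-yl, stayed within the scatter. Since compound 4 returns to a benzyl group, much as in compound 2, no step beyond the scatter is expected for compound 4, and a 1.4-fold higher number from compound 3 to compound 4 (0.14 log units; within the scatter) is the estimated step. Compound 4 is thus expected to give about 3500 nM in this assay, within a range from 1500 nM to 8000 nM.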

Compound 4, half-maximal effective concentration: 2680 nM
For compound 4 the middle estimate is 1.3-fold (0.12 log units) above the measured one; the range from low to high includes it.
By their numbers in this assay, from the lowest: compound 1; then compounds 3, 4 and 2 (each within the scatter of the next).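

In this assay, 3,5-dimethylbenzyl in place of naphthalen-1-yl (a 1.1-fold higher number from compound 3 to compound 4 (0.03 log units; within the scatter)) and 3,5-dimethylphenyl in place of 4-fluorophenyl on the saturated chain carbon (a 1.8-fold lower number from compound 2 to compound 4 (0.25 log units; within the scatter)) both stay within the scatter, so compound 2, compound 3 and compound 4 cannot be ordered. At this position, then, neither one six-membered aromatic ring in place of two nor two methyl groups on the benzyl ring in place of a fluorine gives a step that can be read. The new compound also adds a third aromatic group to the comparison with pentan-3-yl (a 6.5-fold higher number from compound 1 to compound 4 (0.82 log units; beyond the scatter)), a step beyond the scatter, and among these four compounds all three aromatic groups give higher numbers than compound 1, with none going against this.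

No measurement shown offers a reason for these values. The compounds shown leave open where a cyclohexyl group or a shorter alkyl chain such as isopropyl would fall at this position, and whether an amine or a carboxylic acid on the benzyl ring would give a step beyond the scatter.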